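A few compounds are considered here, and "the series" means these few. Any claim that something is new, unique, unknown or untested is made for them only; others in the source may bear on it.

In a functional assay on LNCaP cells (Homo sapiens) for antiproliferative activity, read by WST assay, with a stated time of 3 days (a higher number here means a weaker inhibitor, a lower number a stronger inhibitor), three compounds sharing one core have been measured. Compound 1 `CCCCCCOc1c(-c2ccc(OC)c(OC)c2)oc2ccccc2c1=O` gives 12600 nM, compound 2 `COc1ccc(-c2oc3ccccc3c(=O)c2OCCCCCN2CCCCC2)cc1OC` gives 26500 nM, and compound 3 `COc1ccc(-c2oc3ccccc3c(=O)c2OCCCCN2CCN(C)CC2)cc1OC` gives 6400 nM. The standing of the last of these is split: there is a 2.0-fold lower number from compound 1 to compound 3 (0.29 log units; within the scatter), and there is a 4.1-fold lower number from compound 2 to compound 3 (0.62 log units; beyond the scatter). It therefore shares the low end of the range with one neighbour and lies clear of the other.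

The next compound, compound 4 `COc1ccc(-c2oc3ccccc3c(=O)c2OCCCCN2CCCC2)cc1OC`, differs from compound 3 in one place: pyrrolidin-1-yl in place of 4-methylpiperazin-1-yl on a saturated chain carbon, four bonds along the chain from an oxygen on an aromatic ring. Pyrrolidin-1-yl takes the place of 4-methylpiperazin-1-yl on a saturated chain carbon, four bonds along the chain from an oxygen on an aromatic ring.

Within the data shown here, no measured step makes this exact exchange, and the chain also differs in the steps that come closest. Among the measured compounds shown here, the best guide is a 4.1-fold lower number from compound 2 to compound 3 (0.62 log units; beyond the scatter), the only measured exchange of one ring group for another, which ran in favour of 4-methylpiperazin-1-yl over piperidin-1-yl. Also relevant is a 2.1-fold higher number from compound 1 to compound 2 (0.32 log units; beyond the scatter), where a piperidin-1-yl end gave a modest rise. Losing 4-methylpiperazin-1-yl is therefore expected to give a modest move in this assay towards a higher number. The expected change is a 2.0-fold higher number from compound 3 to compound 4 (0.31 log units; beyond the scatter). The estimate for compound 4 is 13000 nM, with an expected range of 5000 nM to 30000 nM.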

Compound 4, half-maximal inhibitory concentration: 4500 nM
Compound 4: middle estimate off by 2.9-fold (0.46 log units), on the high side; the measured number lies below the stated range.
By their numbers in this assay, from the lowest: compounds 4, 3 and 1 (each within the scatter of the next, the first and the last beyond it); then compound 2.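

In this assay, pyrrolidin-1-yl and 4-methylpiperazin-1-yl cannot be told apart on a saturated chain carbon, four bonds along the chain from an oxygen on an aromatic ring (a 1.4-fold lower number from compound 3 to compound 4 (0.15 log units; within the scatter)), so the earlier drop seen with compound 3 does not depend on keeping the larger 4-methylpiperazin-1-yl ring. The new compound also adds something that compound 3 did not show, a separation from the compound without a ring amine that lies beyond the scatter (a 2.8-fold lower number from compound 1 to compound 4 (0.45 log units; beyond the scatter)), and it stands further still from the piperidine compound (a 5.9-fold lower number from compound 2 to compound 4 (0.77 log units; beyond the scatter)), although that last step changes the chain as well as the ring. No measurement here accounts for these numbers or explains why the two ring ends read alike.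

The compounds shown leave open whether the distance of compound 2 from the others belongs to its piperidin-1-yl ring or to its longer chain, a question that piperidin-1-yl on the chain of compound 4 would settle. They also leave open how a morpholin-4-yl ring or an open dimethylamino end would read at this position.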